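This account rests on a few compounds, and the source may have more. Where it says the series, first, only, none or still open, it means among the compounds named here.

Measured compounds:
compound 1 `COc1ccc(-n2sc(=O)n(-c3ccc(C)cc3)c2=O)cc1` — < 2000 nM
compound 2 `COc1ccc(-n2sc(=O)n(-c3ccccc3)c2=O)cc1` — < 2000 nM

In an ADME assay, in phosphate buffer, with a stated time of 30 min, tested at 1 mM, at a dose of 1 mM (on this read-out lower numbers stand for lower exposure and higher numbers for higher exposure at the dose given), compound 1 gives < 2000 nM, which is a limit of the assay and not a number. In this assay compound 2 gives < 2000 nM, likewise a limit. Compound 2 therefore stands at the limit of < 2000 nM in this assay, at which 2 of the 2 values shown sit, and no number below that limit is known for it. Among the measured compounds shown here, the one measured step, a step that the two limits leave unreadable from compound 1 to compound 2, cannot be read, as both of its ends are limits.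

Compound 3 `COc1ccc(-n2sc(=O)n(Cc3ccccc3)c2=O)cc1` differs from compound 2 by benzyl in place of phenyl on an aromatic nitrogen. For the measured compounds named here, no measured step matches this change, and the single step that exists, a step that the two limits leave unreadable from compound 1 to compound 2, gives no size to lean on. The only footing is that both measured compounds sit at the same limit.

Compound 3 is expected to remain near that limit, with an expected step that the limit leaves unreadable from compound 2 to compound 3 that does not go beyond the scatter. The estimate for compound 3 in this assay is 1000 nM, in the range 200 nM to 3000 nM.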

Compound 3, maximal plasma concentration: 5490 nM
Compound 3: the middle estimate sits 5.5-fold (0.74 log units) below what was measured, outside the stated range (above it).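

In this assay, compound 3 is the only compound shown with a value that is a number and not a limit, so exposure at this dose is now seen to respond to the group on the aromatic nitrogen. Benzyl in place of phenyl gives an at least 2.7-fold higher number from compound 2 to compound 3 (0.43 log units; beyond the scatter), and benzyl in place of 4-methylphenyl gives an at least 2.7-fold higher number from compound 1 to compound 3 (0.43 log units; beyond the scatter); the true size of each step stays unknown, as each starts from a limit. The two compounds with the ring carried directly on the nitrogen remain limits: the limit of < 2000 nM in this assay, at which 2 of the 3 values shown sit.

Still open, going by these compounds, is whether a longer chain ending in phenyl would go further than benzyl, or whether the gain survives an amine or a carboxylic acid on the benzyl ring. The compounds shown also say nothing about changes elsewhere on the shared core.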